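Compound 3 after two readings at the limit

This account rests on a few compounds, and the source may have more. Where it says the series, first, only, none or still open, it means among the compounds named here.

In an ADME assay on BaF3 cells (Mus musculus) for antiproliferative activity, read by CCK-8 assay, with a stated time of 72 h (a lower number here means a stronger inhibitor of growth, a higher number a weaker inhibitor of growth), compound 1 (`Cc1cccc(NC(=O)CCSc2ccc3c(/C=C/c4ccccn4)n[nH]c3c2)c1`) gives > 10000 nM, which is a limit of the assay. Compound 2 (`CN(C)c1cccc(NC(=O)CCSc2ccc3c(/C=C/c4ccccn4)n[nH]c3c2)c1`) gives > 10000 nM, which is also a limit. Together they form (the limit of > 10000 nM in this assay, at which 2 of the 2 values shown sit). Compound 3 (`O=C(CCSc1ccc2c(/C=C/c3ccccn3)n[nH]c2c1)NCc1cccc(C(F)(F)F)c1`) carries this change: 3-(trifluoromethyl)benzyl in place of 3-(dimethylamino)phenyl on an amide-type nitrogen. For the measured compounds named here, the only measured step, a step that the two limits leave unreadable from compound 1 to compound 2, offers no size to carry over, so no clear shift in either direction is expected. The estimated step is a number no higher from compound 2 to compound 3 (the limit leaves the size open). Compound 3 is expected near 10000 nM, with an estimated range from 3000 nM to 30000 nM, and another limit reading is likely.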

Compound 3, concentration for 50% growth inhibition: 8030 nM
Estimate against measurement, compound 3: 1.2-fold (0.10 log units) above, within the range that was stated.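

Placing 3-(trifluoromethyl)benzyl on the amide-type nitrogen gives the only reading in this assay that is a number and not a limit. The steps are an at least 1.2-fold lower number from compound 2 to compound 3 (0.09 log units; that floor lies within the scatter) and an at least 1.2-fold lower number from compound 1 to compound 3 (0.09 log units; that floor lies within the scatter); each is only a floor, so neither shows a real gain in growth inhibition. The other two readings remain limits, so the true size of each step stays unknown: the limit of > 10000 nM in this assay, at which 2 of the 3 values shown sit.

From the compounds shown here alone, whether an amine or a carboxylic acid in place of the trifluoromethyl group would move the number stays open. So does the effect of a longer chain in place of the benzyl group.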